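The compounds below may be only part of what the source reports. "The series", "measured", "known", "first", "only" and "open" are said of these compounds alone.

Two compounds from this series have structures in hand. Compound 1, `CS(=O)(=O)c1nn2cc(-c3cc4ccccc4o3)nc2s1`, carries a methylsulfonyl group on the shared core, and in an ADME assay on microsomes from liver (Homo sapiens) for metabolic stability, with a stated time of 10 min (a higher number here means that more of the compound is left, a lower number that less of the compound is left), compound 1 is recorded as "not determined" (no result reported), so nothing can be said of it beyond its structure. For the measured compounds named here, compound 2, `COc1cc(OCc2cccc(COc3ccccc3)c2)c2cc(-c3cn4nc(OC)sc4n3)oc2c1`, is the only compound with a number here: in this assay compound 2 gives 86%, a high fraction of the compound remaining after the stated time. Going by the values given here, with only one number and one entry without a result, compound 2 stands alone, and no comparison between measured compounds is possible.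

Compound 3, `COc1cc(OCc2cccc(Sc3ccccc3)c2)c2cc(-c3cn4nc(OC)sc4n3)oc2c1`, is the unmeasured follow-up. It differs from compound 2 in one place: phenylsulfanyl in place of phenoxymethyl on an aromatic carbon. Among the compounds with values here, no measured pair in this set shows what such a change does in this assay, so the expectation has to rest on compound 2 alone. The expected step of a number 6 percentage points lower from compound 2 to compound 3 (within the scatter) is small, not beyond the usual scatter of repeated measurements. Compound 3 is therefore estimated at 80%, with a range from 60% to 95%.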

Compound 3, percent of the compound remaining: 80%
Compound 3: middle estimate and measured number agree at the digits printed; the measured number falls inside the stated range.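

In this assay, for the compounds shown here, the swap of phenoxymethyl for phenylsulfanyl gives a number 6 percentage points lower from compound 2 to compound 3 (within the scatter) and is the first reading at this position, an aromatic carbon meta to a large group. The two compounds cannot be told apart in this assay, even though the group that leaves has 8 heavy atoms with one oxygen and the group that enters has 7 with one sulfur, so this particular exchange at this position has no effect that the measurement can resolve. No measurement that could point to a reason for this result is available.

The compounds shown keep a six-membered aromatic ring of carbon only in this group, so they leave open how the same position would respond to a group without that ring, such as an amine, a carboxylic acid or a longer alkyl chain. This single pair also cannot show whether the exchange of phenoxymethyl for phenylsulfanyl would read the same way at another place on the molecule or on a different core.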